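The source may report more compounds than this note shows. Statements on the series, on what has been measured and on what is new or still open speak of the compounds shown alone.

Compound 1 `CC(C)=CC[C@H](OC(=O)C=C(C)C)C1=CC(=O)c2c(O)ccc(O)c2C1=O`: 320 nM
Compound 2 `COc1ccc(O)c2c1C(=O)C(CCC=C(C)C)=CC2=O`: 5110 nM
Compound 3 `COc1ccc(O)c2c1C(=O)C=C([C@H](CC=C(C)C)OC(C)=O)C2=O`: 90 nM

In a functional assay on MDA-MB-231 cells (Homo sapiens) for cytotoxicity, read by MTT assay, with a stated time of 48 h (a higher number here means a weaker inhibitor, a lower number a stronger inhibitor), compound 1 gives 320 nM, the second highest of the three numbers. Its nearest neighbour is compound 3, which gives 90 nM, a gap beyond the usual scatter; the furthest is compound 2, which gives 5110 nM, also well beyond the scatter. The unmeasured compound 4 `COc1ccc(O)c2c1C(=O)C=C([C@H](CC=C(C)C)OC(=O)C=C(C)C)C2=O` differs from compound 1 by methyl in place of hydrogen on an oxygen on an aromatic ring. Within the data shown here, no measured pair shows this single change on its own, so its size cannot be read directly from the data. A modest step towards a lower number in this assay is nonetheless expected, because compound 3 gives 90 nM. Compound 4 is therefore estimated at 150 nM, with a range from 40 nM to 600 nM. This estimate means an expected step of a 2.1-fold lower number from compound 1 to compound 4 (0.33 log units; beyond the scatter).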

Compound 4, half-maximal inhibitory concentration: 260 nM
For compound 4 the middle estimate is 1.7-fold (0.24 log units) below the measured one; the range from low to high includes it.
By their numbers in this assay, from the lowest: compound 3; then compounds 4 and 1 (each within the scatter of the next); then compound 2.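

In this assay, methyl in place of hydrogen on an oxygen on an aromatic ring leaves the two compounds within the usual scatter of each other, with a 1.2-fold lower number from compound 1 to compound 4 (0.09 log units; within the scatter), so this hydroxy to methoxy swap shows no clear effect here. The group on the carbonyl carbon matters more: 2-methylprop-1-en-1-yl in place of methyl gives a 2.9-fold higher number from compound 3 to compound 4 (0.46 log units; beyond the scatter), a modest step beyond the scatter. No measurement shown explains either step.

Still open, from the compounds shown here alone, is whether a longer chain on that oxygen would keep this level of activity. Going by these compounds, it is also open how an amine on the carbonyl carbon would compare.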